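Swapping dichlorophenyl for methoxyphenyl on a quinoxaline diamine

The source may hold more compounds than are shown below. What is called first, only, known or untested is meant among the compounds shown, and "the series" means these compounds.

Compound 1 `CCOC(=O)[C@H](CCC(=O)O)NC(=O)c1ccc(CNc2nc3cc(N)cc(N)c3nc2-c2ccccc2)cc1` gives < 100000 nM in a functional assay on SK-OV-3 cells (Homo sapiens) for inhibition, read by sulforhodamine B assay, with a stated time of 48 h (on this read-out higher numbers stand for weaker inhibition of growth and lower numbers for stronger inhibition of growth), a limit of the assay and not a number.
Compound 2 `Nc1cc(N)c2nc(-c3ccccc3)c(NCc3ccc(Cl)c(Cl)c3)nc2c1` gives 36300 nM in this assay.
Compound 3 `CCOC(=O)[C@H](CCC(=O)O)NC(=O)c1ccc(Sc2nc3cc(N)cc(N)c3nc2-c2ccccc2)cc1` gives 44700 nM in this assay.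

Among the compounds with values here, only two of the three values are numbers, and compound 2 gives one of them; compound 3 gives a number that sits within the usual scatter of it, so the two cannot be told apart. Within the data shown here, compound 1 reports only a limit, as the one value that sits at the limit of < 100000 nM in this assay, at which 1 of the 3 values shown sits.

The unmeasured compound 4 `COc1ccc(CNc2nc3cc(N)cc(N)c3nc2-c2ccccc2)cc1` differs from compound 2 in a single place: 4-methoxyphenyl in place of 3,4-dichlorophenyl on a saturated chain carbon bound to a nitrogen on an aromatic ring. Among the measured compounds shown here, no measured pair in this set differs in just that way, so the size of the step has to be guessed from the weak inhibition that the whole set shows. Nothing in the measured compounds points to a strong change in either direction, and a step from compound 2 to compound 4 of about a 1.5-fold higher number from compound 2 to compound 4 (0.18 log units; within the scatter) is expected, within or just beyond the scatter, toward weaker inhibition. For compound 4 in this assay a value of 55000 nM is estimated, with a likely range from 20000 nM to 150000 nM.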

Compound 4, concentration for total growth inhibition: 57500 nM
Estimate against measurement, compound 4: 1.0-fold (0.02 log units) below; low and high end bracket the measured number.
By their numbers in this assay, from the lowest: compounds 2, 3 and 4 (each within the scatter of the next).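

Within the data shown here, this is the first pair in the set that differs in one place only, so it gives the first direct reading at this position, on a saturated chain carbon bound to a nitrogen on an aromatic ring. Replacing 3,4-dichlorophenyl with 4-methoxyphenyl gives a 1.6-fold higher number from compound 2 to compound 4 (0.20 log units; within the scatter), so in this assay the two compounds cannot be told apart, even though two chlorines give way to a methoxy group that brings a hydrogen-bond acceptor. This is a comparison of two numbers, as neither compound sits at the limit of the assay: the limit of < 100000 nM in this assay, at which 1 of the 4 values shown sits.

The compounds shown leave open whether any group on this ring can move the value beyond the scatter, such as an amine or a carboxylic acid. They also leave open what a longer chain between the ring and the nitrogen would do.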